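The source may report more compounds than this note shows. Statements on the series, on what has been measured and on what is new or still open speak of the compounds shown alone.

Measured so far in a functional assay on KYSE-410 cells (Homo sapiens) for antiproliferative activity, read by MTT assay, with a stated time of 72 h; on this read-out lower numbers stand for stronger inhibition and higher numbers for weaker inhibition:
Compound 1, `O=C(Nc1cccc(F)c1)c1cc(=O)[nH]c2cc(Br)ccc12`, gives 7300 nM.
Compound 2, `O=C(Nc1cccc(Cl)c1)c1cc(=O)[nH]c2cc(Br)ccc12`, gives only a limit of the assay, > 20000 nM.
Compound 3, `O=C(Nc1cc(F)cc(F)c1)c1cc(=O)[nH]c2cc(F)ccc12`, gives only a limit of the assay, > 20000 nM.

Among the compounds with values here, the one measured step is chloro in place of fluoro on an aromatic carbon, which gives an at least 2.7-fold higher number from compound 1 to compound 2 (0.43 log units; beyond the scatter). Compound 4, `O=C(Nc1cc(F)cc(F)c1)c1cc(=O)[nH]c2cc(Cl)ccc12`, differs from compound 3 by chloro in place of fluoro on an aromatic carbon. The two changes are the same kind of change, not the same: the first sits on a six-membered aromatic ring of carbon only, meta to a large group; the second on a ring of carbon only that is part of a fused or bridged system of two rings, meta to a fused ring and para to a fused ring. The difference between the two cores, compound 3 against compound 1, is not broken down here. Two of the three values sit at the limit of > 20000 nM in this assay, at which 2 of the 3 values shown sit, so little room for movement is visible in this assay. For compound 4 the step that the limit leaves unreadable from compound 3 to compound 4 is expected, resting on the earlier exchange of fluoro for chloro giving an at least 2.7-fold higher number from compound 1 to compound 2 (0.43 log units; beyond the scatter) in the direction of weaker inhibition. Compound 4 is therefore expected at 30000 nM, between 12000 nM and 80000 nM, most likely reported again as a limit.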

Compound 4, half-maximal inhibitory concentration: 11000 nM
For compound 4 the middle estimate is 2.7-fold (0.44 log units) above the measured one, and the stated range ends above it.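

In this assay chloro in place of fluoro on the fused system gives an at least 1.8-fold lower number from compound 3 to compound 4 (0.25 log units; that floor lies within the scatter) and so does not match the same kind of exchange on the other ring, which points the opposite way: the same change on two cores in this assay, an at least 2.7-fold higher number (0.43 log units; beyond the scatter) from compound 1 to compound 2 and an at least 1.8-fold lower number (0.25 log units; that floor lies within the scatter) from compound 3 to compound 4, at least 4.9-fold (0.69 log units) apart, beyond the scatter of two such steps.

The exchange therefore does not carry from the core of compound 1 to the core of compound 3 as a fixed shift, and a reading from one pair cannot be transferred to the other; the notes show only this disagreement, across two pairs, and do not separate the ring carrying the exchange from the other differences between the cores. Neither step has a true size, since each has one end at a limit: the limit of > 20000 nM in this assay, at which 2 of the 4 values shown sit.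

Open, from the compounds shown here alone, is whether the direction of the step follows the ring that carries the exchange or the rest of the core. Also open, going by these compounds, is how a methoxy group or an amine would read at these same places on either core.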